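The source may report more compounds than this note shows. Statements on the series, on what has been measured and on what is new or still open speak of the compounds shown alone.

Compound 1 `N#C/N=C1\N(CCCCCCOc2ccc(Cl)cc2)C(=O)CN1c1ccncc1` is the starting point here. In a functional assay on HONE1 cells for cytotoxicity against HONE1 cell line (Homo sapiens) (a lower number here means a stronger inhibitor, a higher number a weaker inhibitor), compound 1 gives 2960 nM. Compound 2 `N#C/N=C1\N(CCCCCCCOc2ccc(Cl)cc2)C(=O)CN1c1ccncc1` differs from it only by (4-chlorophenoxy)methyl in place of 4-chlorophenoxy on a saturated chain carbon, six bonds along the chain from an amide-type nitrogen in a ring, and this change gave a 1.1-fold higher number from compound 1 to compound 2 (0.04 log units; within the scatter), so compound 2 gives 3240 nM in this assay. A different change leads to compound 3 `CC1C(=O)N(CCCCCCOc2ccc(Cl)cc2)/C(=N\C#N)N1c1ccncc1`, whose core differs from that of compound 1 by methyl in place of hydrogen on a saturated ring carbon; this gave a 9.8-fold lower number from compound 1 to compound 3 (0.99 log units; beyond the scatter), and compound 3 gives 303 nM in this assay.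

Compound 4 `CC1C(=O)N(CCCCCCCOc2ccc(Cl)cc2)/C(=N\C#N)N1c1ccncc1` has not yet been measured. It differs from compound 3 by (4-chlorophenoxy)methyl in place of 4-chlorophenoxy on a saturated chain carbon, six bonds along the chain from an amide-type nitrogen in a ring, the same change that was made from compound 1 to compound 2, at the same place. Because that earlier change gave a 1.1-fold higher number from compound 1 to compound 2 (0.04 log units; within the scatter), a step of about a 1.1-fold higher number from compound 3 to compound 4 (0.05 log units; within the scatter) is expected from compound 3 to compound 4 in this assay. Compound 4 is therefore estimated to give 340 nM, with a range from 180 nM to 650 nM.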

Compound 4, half-maximal inhibitory concentration: 371 nM
For compound 4 the middle estimate is 1.1-fold (0.04 log units) below the measured one; measured number inside the range.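

The step from 4-chlorophenoxy to (4-chlorophenoxy)methyl, a 1.2-fold higher number from compound 3 to compound 4 (0.09 log units; within the scatter) in this assay, behaves as it did on the core without the ring methyl: the same change on two cores in this assay, a 1.1-fold higher number (0.04 log units; within the scatter) from compound 1 to compound 2 and a 1.2-fold higher number (0.09 log units; within the scatter) from compound 3 to compound 4, 1.1-fold (0.05 log units) apart, within the scatter of two such steps. The ring methyl, an 8.7-fold lower number from compound 2 to compound 4 (0.94 log units; beyond the scatter), likewise keeps its size on the longer chain: the same change on two cores in this assay, a 9.8-fold lower number (0.99 log units; beyond the scatter) from compound 1 to compound 3 and an 8.7-fold lower number (0.94 log units; beyond the scatter) from compound 2 to compound 4, 1.1-fold (0.05 log units) apart, within the scatter of two such steps. In these four compounds the two changes therefore act independently of each other, but this rests on a single set of four compounds in one cell assay and does not show that either change would carry over to other cores.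

On these data alone, it remains open whether an ethyl group on the same ring carbon would go further than methyl. As far as these compounds go, whether a much shorter or much longer chain would fit the same pattern is also open.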